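Swapping the (4-Fluorobenzyl)oxy Group for 2-Chloro-4-fluorophenyl

The source may hold more compounds than are shown below. What is called first, only, known or untested is meant among the compounds shown, and "the series" means these compounds.

Compound 1, `Cc1nn(-c2ncnc3nc[nH]c23)c2c1C(OCc1ccc(C#N)cc1)CC(=O)N2`: 4 nM
Compound 2, `Cc1nn(-c2ncnc3nc[nH]c23)c2c1C(OCc1ccc(F)cc1)CC(=O)N2`: 1 nM

Both compounds were tested in a functional assay on HEK293 cells for agonist activity at G-protein coupled receptor 39 (Homo sapiens), read by scintillation proximity assay and inositol phosphate accumulation, with a stated time of 75 min, in the presence of a further agent that is not named here; on this read-out lower numbers stand for an effect already at smaller amounts and higher numbers for an effect only at larger amounts of compound. Among the measured compounds shown here, the one measured step is a 4.0-fold lower number from compound 1 to compound 2 (0.60 log units; beyond the scatter), and it is what places compound 2 at the lowest of the two numbers. Compound 3, `Cc1nn(-c2ncnc3nc[nH]c23)c2c1C(c1ccc(F)cc1Cl)CC(=O)N2`, differs from compound 2 in one place: 2-chloro-4-fluorophenyl in place of (4-fluorobenzyl)oxy on a saturated ring carbon. The measured step from compound 1 to compound 2 changed only a substituent on the aromatic ring and kept the ether linkage to the saturated ring carbon; it does not speak to a change that removes that linkage and attaches the ring directly. For the measured compounds named here, no measured pair shows what such a change does, so the expectation can only be loosely bounded. Compound 3 is estimated at 5 nM, with an expected range from 1 nM to 30 nM. That estimate corresponds to an expected step of a 5.0-fold higher number from compound 2 to compound 3 (0.70 log units; beyond the scatter), with the wide range reflecting the absence of any measured precedent.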

Compound 3, half-maximal effective concentration: 9 nM
Beside the measured number, compound 3's estimate is 1.8-fold (0.26 log units) below it; the measured number falls inside the stated range.
By their numbers in this assay, from the lowest: compound 2; then compound 1; then compound 3.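

In this assay, the saturated ring carbon can carry an aromatic ring attached directly, without the ether link, and the compound keeps its effect in the nanomolar range, but replacing the (4-fluorobenzyl)oxy group with 2-chloro-4-fluorophenyl gives a 9.0-fold higher number from compound 2 to compound 3 (0.95 log units; beyond the scatter). Replacing the (4-cyanobenzyl)oxy group in the same way gives a 2.3-fold higher number from compound 1 to compound 3 (0.35 log units; beyond the scatter), so the new group gives a higher number than either ether-linked group, and both steps lie beyond the usual scatter. Nothing measured here explains these steps.

Because the ether link left and a chlorine arrived in one change, the share of each in the step cannot be separated. Going by these compounds, it also remains open how a plain 4-fluorophenyl group, or an amine or a carboxylic acid, would behave on this saturated ring carbon.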